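This account rests on a few compounds, and the source may have more. Where it says the series, first, only, none or still open, it means among the compounds named here.

Measured so far:
- compound 1 (`CCCCN1CCN(CCCCn2c3c(c4ccccc42)C(=O)c2c[n+]([O-])c4ccccc4c2C3=O)CC1`) gives 6100 nM
- compound 2 (`CN1CCN(CCCn2c3c(c4ccccc42)C(=O)c2c[n+]([O-])c4ccccc4c2C3=O)CC1`) gives 560 nM

In a functional assay on SH-SY5Y cells (Homo sapiens) for cytotoxicity, read by MTT assay, with a stated time of 72 h (on this read-out higher numbers stand for weaker inhibition and lower numbers for stronger inhibition), compound 2 holds the lower of the two numbers. Compound 3 (`O=C1c2c[n+]([O-])c3ccccc3c2C(=O)c2c1c1ccccc1n2CCN1CCCCC1`) carries piperidin-1-yl in place of (4-methylpiperazin-1-yl)methyl on a saturated chain carbon, two bonds along the chain from an aromatic nitrogen. Among the measured compounds shown here, one measured step bears on this (an 11-fold lower number from compound 1 to compound 2 (1.04 log units; beyond the scatter)), a large one beyond the scatter, but it involves a different change. Hence no step beyond the scatter is expected (a 1.2-fold lower number from compound 2 to compound 3 (0.07 log units; within the scatter)). In this assay compound 3 is expected at 480 nM with 140 nM to 1700 nM as its estimated range.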

Compound 3, half-maximal inhibitory concentration: 1860 nM
The estimate for compound 3 lay 3.9-fold (0.59 log units) below the measured number, and the stated range ends below it.
By their numbers in this assay, from the lowest: compound 2; then compound 3; then compound 1.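

At the saturated chain carbon two bonds along the chain from an aromatic nitrogen, the swap to piperidin-1-yl gives, in this assay, a 3.3-fold higher number from compound 2 to compound 3 (0.52 log units; beyond the scatter), while the change from the longer butylpiperazine side chain gives a 3.3-fold lower number from compound 1 to compound 3 (0.52 log units; beyond the scatter). Among the compounds shown here, the position therefore responds to more than the one change seen earlier, with compound 3 lying between the other two. No evidence here accounts for either step. Ring and chain length change together in these steps, so their shares remain open; a 2-(4-methylpiperazin-1-yl)ethyl group on the aromatic nitrogen would separate them.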